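This account rests on a few compounds, and the source may have more. Where it says the series, first, only, none or still open, it means among the compounds named here.

Measured so far in a physicochemical assay for solubility, measured as kinetic solubility (on this read-out higher numbers stand for higher solubility and lower numbers for lower solubility), are these compounds:

- compound 1 `Cc1cc(C)c(CN2CCc3c(Cl)cc(C(CO)c4ccon4)c(Cl)c3C2=O)c(=O)[nH]1` gives 596000 nM; 481000 nM (2 entries) as its entries
- compound 2 `COC(c1cc(Cl)c2c(c1Cl)C(=O)N(Cc1c(C)cc(C)[nH]c1=O)CC2)C1CCS(=O)(=O)CC1` gives 373000 nM; 415000 nM (2 entries) as its entries
- compound 3 `Cc1cc(C)c(CN2CCc3c(Cl)cc([C@@H](CO)[C@@H]4CCOC4)c(Cl)c3C2=O)c(=O)[nH]1` gives 537000 nM as its one number

Compound 3 also has two further entries that yield no single number. Within the data shown here, its one value lies within the scatter of the entries for compound 1 and compound 2, so the three compounds cannot be ranked in this assay. Among the measured compounds shown here, no step between measured compounds that differ in one place is available either.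

The next compound is compound 4 `Cc1cc(C)c(CN2CCc3c(Cl)cc(-c4c(C)noc4C)c(Cl)c3C2=O)c(=O)[nH]1`. Relative to compound 3, the change is a group of 7 heavy atoms (5 carbon, 1 nitrogen, 1 oxygen; one five-membered aromatic ring with 2 hetero atoms) in place of a group of 8 heavy atoms (6 carbon, 2 oxygen; one five-membered non-aromatic ring with 1 hetero atom), on an aromatic carbon and puts 3,5-dimethyl-1,2-oxazol-4-yl on an aromatic carbon of the shared core. All three measured compounds have a saturated carbon attached at this aromatic carbon, compound 3 at 537000 nM among them, and compound 4 alone lacks one. For the measured compounds named here, that structural difference is the only basis for a direction, and no measured pair supports it. A drop beyond the scatter is therefore expected, though loosely. The estimated change is a 3.6-fold lower number from compound 3 to compound 4 (0.55 log units; beyond the scatter) in this assay, a moderate fall with wide uncertainty. Compound 4 is expected at 150000 nM in this assay, with an estimated range from 40000 nM to 450000 nM as the working bounds.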

Compound 4, solubility: 93000 nM
The estimate for compound 4 lay 1.6-fold (0.21 log units) above the measured number; low and high end bracket the measured number.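

Among these compounds, the first readable step in this assay lies on the aromatic carbon ortho to a chloro group, where 3,5-dimethyl-1,2-oxazol-4-yl replaces the group carried by compound 3, and it gives a 5.8-fold lower number from compound 3 to compound 4 (0.76 log units; beyond the scatter) in this series. Among the compounds shown here, this shows that the read-out responds to a change at this position, which the earlier compounds could not show with no step between them. For the compounds shown here, the single exchange alters several things at once: a saturated carbon no longer sits on the aromatic carbon, the five-membered ring becomes aromatic, the hydrogen-bond donor count falls from 1 to 0, and the 2 defined stereocentres go, so the step cannot be assigned to any one of these. Repeat entries of one compound stay close together, so the step is not simply spread between repeats: the several entries of compound 1 in this assay, 596000 nM; 481000 nM (2 entries)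

Still open, from the compounds shown here alone, is whether the fall follows from the aromatic ring being attached directly or from the loss of the hydroxymethyl arm, which a directly attached tetrahydrofuran ring or a hydroxymethyl group alone on this carbon would separate. Going by these compounds alone, also open is how a basic amine such as piperidine or a carboxylic acid at this position would read, and the step rests on only one numeric value for compound 3.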